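A few compounds are considered here, and "the series" means these few. Any claim that something is new, unique, unknown or untested is made for them only; others in the source may bear on it.

In a functional assay on CHO cells for antagonist activity at C-X-C chemokine receptor type 3 (Homo sapiens), read by GTPgammaS binding (on this read-out higher numbers stand for weaker inhibition and lower numbers for stronger inhibition), compound 1 `COC(=O)c1cccc(NC(=O)NC2CCN(C/C3=C/CCCCCC3)CC2)c1` gives 660 nM, compound 2 `COc1cccc(NC(=O)NC2CCN(CC3=CC[C@H]4C[C@@H]3C4(C)C)CC2)c1` gives 429 nM, and compound 3 `CC1(C)[C@H]2CC=C(CN3CCC(NC(=O)Nc4ccc(-c5ccc(C(F)(F)F)cc5)s4)CC3)[C@@H]1C2` gives 39 nM, the lowest of the three numbers; its gaps to compound 2 and to compound 1 both lie beyond the usual scatter. Compound 4 `COc1cccc(-c2ccc(NC(=O)NC3CCN(CC4=CC[C@H]5C[C@@H]4C5(C)C)CC3)s2)c1` differs from compound 3 in a single place: 3-methoxyphenyl in place of 4-(trifluoromethyl)phenyl on an aromatic carbon. Among the compounds with values here, no measured pair shows this exact change, so its size cannot be read from the data. Compound 2 also carries a 3-methoxyphenyl group, though attached in a different way, and gives 429 nM, a higher number than compound 3. For compound 4 a modest weakening in this assay is expected, a 2.8-fold higher number from compound 3 to compound 4 (0.45 log units; beyond the scatter). Compound 4 is estimated at 110 nM in this assay, within a range from 30 nM to 400 nM.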

Compound 4, inhibition constant: 29 nM
The estimate for compound 4 lay 3.8-fold (0.58 log units) above the measured number; measured number outside the range, below it.
By their numbers in this assay, from the lowest: compounds 4 and 3 (each within the scatter of the next); then compounds 2 and 1 (each within the scatter of the next).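

At the aromatic carbon next to the ring sulfur, 3-methoxyphenyl in place of 4-(trifluoromethyl)phenyl gives a 1.3-fold lower number from compound 3 to compound 4 (0.13 log units; within the scatter) in this assay on this read-out. This position therefore takes either substituted phenyl ring with no difference that can be told from the scatter, although only the entering group holds a hydrogen-bond acceptor. Nothing on hand explains this match. Open, from the compounds shown here alone, is whether a pyridine ring would fit here as well as these phenyl rings. Open too, going by these compounds, is how a carboxylic acid or an amine on the phenyl ring would read.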